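A Methyl Step Repeated on a Second Core

This account rests on a few compounds, and the source may have more. Where it says the series, first, only, none or still open, it means among the compounds named here.

Compound 1 `O=C1OCCN1CC#CCn1ccnc1` and compound 2 `Cc1cncn1CC#CCN1CCOC1=O` share one core and differ by methyl in place of hydrogen on an aromatic carbon. In a functional assay on the whole organism for antagonist activity, with Mus musculus as the target (on this read-out higher numbers stand for an effect only at larger amounts of compound and lower numbers for an effect already at smaller amounts), compound 1 gives only a limit of the assay, > 100 mg/kg. In this assay compound 2 gives 80 mg/kg. The change between them made an at least 1.2-fold lower number from compound 1 to compound 2 (0.09 log units; that floor lies within the scatter), so this step is not separated from the scatter of repeated measurements.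

Compound 3 `Cn1ccn(CC#CCn2ccnc2)c1=O` carries a different core; how that core differs from the core of compound 1 is not broken down here. In this assay compound 3 gives only a limit, > 100 mg/kg. Across the measured set there stands (the limit of > 100 mg/kg in this assay, at which 2 of the 3 values shown sit).

Compound 4 `Cc1cncn1CC#CCn1ccn(C)c1=O` has not yet been measured in this assay. It differs from compound 3 by methyl in place of hydrogen on an aromatic carbon, the same change that leads from compound 1 to compound 2, at a place described in the same words. The study expects a number no higher from compound 3 to compound 4 (the limit leaves the size open), resting on the small step recorded as an at least 1.2-fold lower number from compound 1 to compound 2 (0.09 log units; that floor lies within the scatter). On that basis compound 4 is expected to give about 100 mg/kg in this assay, estimated to fall between 40 mg/kg and 300 mg/kg.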

Compound 4, dose for half-maximal effect: 22 mg/kg
Compound 4: middle estimate off by 4.5-fold (0.66 log units), on the high side; the whole stated range lies above it.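

In this assay, methyl in place of hydrogen on an aromatic carbon gives an at least 4.5-fold lower number from compound 3 to compound 4 (0.65 log units; beyond the scatter), so on the core of compound 3 the change stands clear of the scatter. Both steps point towards a lower number, but only this one is separated from the scatter, and the data do not show that the change is worth the same on both cores: the same change on two cores in this assay, an at least 1.2-fold lower number (0.09 log units; that floor lies within the scatter) from compound 1 to compound 2 and an at least 4.5-fold lower number (0.65 log units; beyond the scatter) from compound 3 to compound 4; the limit leaves it open whether they differ Compound 1 and compound 3 each start from a limit rather than a number, so the full size of neither step can be read, and two cores are too few to show how generally the change carries over: the limit of > 100 mg/kg in this assay, at which 2 of the 4 values shown sit.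

The compounds shown leave open whether a group other than methyl, such as ethyl, a longer chain or a chlorine atom, would do the same at this place on the ring. They also leave open what an amine or a carboxylic acid would do there on either core.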